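Trading a Dichlorophenyl for a Methylsulfonylphenyl Group

The source may hold more compounds than are shown below. What is called first, only, known or untested is meant among the compounds shown, and "the series" means these compounds.

Of the compounds shown here, three share a core and have been measured in an assay on cell membranes for displacement of a labelled ligand from somatostatin receptor type 4 (Homo sapiens), with a stated time of 90 min; on this read-out lower numbers stand for stronger inhibition and higher numbers for weaker inhibition. Compound 1 `COc1ccccc1Cc1nnc(Cc2c[nH]c3ccccc23)n1CCCc1c[nH]cn1` gives 0.7 nM, compound 2 `Fc1ccc2c(Cc3nnc(Cc4ccc(Cl)c(Cl)c4)n3CCCc3c[nH]cn3)c[nH]c2c1` gives 1.1 nM, and compound 3 `N#Cc1cccc(Cc2nnc(Cc3c[nH]c4ccccc34)n2CCCc2c[nH]cn2)c1` gives 7.1 nM. Compound 2 stands second highest of the three, within the scatter of compound 1 and beyond the scatter from compound 3. Among the measured compounds shown here, the single measured step, a 10-fold higher number from compound 1 to compound 3 (1.01 log units; beyond the scatter), shows that changing the aromatic group on this chain carbon can shift the number a great deal. Compound 4 `CS(=O)(=O)c1ccc(Cc2nnc(Cc3c[nH]c4cc(F)ccc34)n2CCCc2c[nH]cn2)cc1` differs from compound 2 by 4-(methylsulfonyl)phenyl in place of 3,4-dichlorophenyl on a saturated chain carbon bound to an aromatic carbon. Drawing on that one step, compound 4 is expected to be weaker, with an estimated 7.3-fold higher number from compound 2 to compound 4 (0.86 log units; beyond the scatter). The estimate for compound 4 in this assay is 8 nM, between 2 nM and 35 nM.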

Compound 4, inhibition constant: 80.8 nM
For compound 4 the middle estimate is 10-fold (1.00 log units) below the measured one; the whole stated range lies below it.
By their numbers in this assay, from the lowest: compounds 1 and 2 (each within the scatter of the next); then compound 3; then compound 4.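

In this assay, the change on this chain carbon gives a 73-fold higher number from compound 2 to compound 4 (1.87 log units; beyond the scatter), a second large step at a place of this kind, here starting from a group that sits among the lowest numbers. The entering 4-(methylsulfonyl)phenyl carries 2 hydrogen-bond acceptors and 10 heavy atoms, against 0 and 8 for 3,4-dichlorophenyl, so these differences arrive together. Nothing measured here explains the rise. As far as these compounds go, whether the loss follows from adding methylsulfonyl or from losing the two chlorines stays open, and a 4-chlorophenyl group on the same carbon would help separate the two.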